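This account rests on a few compounds, and the source may have more. Where it says the series, first, only, none or still open, it means among the compounds named here.

Three compounds have been measured in a functional assay on A549 cells (Homo sapiens) for antiproliferative activity, read by MTT assay, with a stated time of 48 h; on this read-out lower numbers stand for stronger inhibition and higher numbers for weaker inhibition:

compound 1 `CCNCC(=O)Nc1cc(OC)ccc1C(=O)c1ccc2c(c1)C=CC(C)(C)O2` gives 1300 nM
compound 2 `COc1ccc(C(=O)c2ccc3c(c2)C=CC(C)(C)O3)c(NC(=O)CN(C)C)c1` gives 1160 nM
compound 3 `C=C(c1ccc(OC)cc1NC(=O)CNCC)c1ccc(OC)c2c1OC(C)(C)C=C2` gives 970 nM

Compound 1 and compound 2 share one core and differ only at the amine on the side chain: dimethylamino in place of ethylamino on a saturated chain carbon bound to a carbonyl carbon. In this assay that change gave a 1.1-fold lower number from compound 1 to compound 2 (0.05 log units; within the scatter), so the two compounds sit within the usual scatter of each other. Compound 3 is built on a second core; how that core differs from the core of compound 1 is not broken down here. Compound 4 `C=C(c1ccc(OC)cc1NC(=O)CN(C)C)c1ccc(OC)c2c1OC(C)(C)C=C2` has not yet been measured. It stands to compound 3 as compound 2 stands to compound 1: dimethylamino in place of ethylamino on a saturated chain carbon bound to a carbonyl carbon, at the same place as before, so it is the same change carried over to the second core. Among the compounds with values here, with only one earlier instance to go on, a step of about the same size is expected, that is a 1.1-fold lower number from compound 3 to compound 4 (0.04 log units; within the scatter), because the earlier step was a 1.1-fold lower number from compound 1 to compound 2 (0.05 log units; within the scatter). On that basis compound 4 is estimated to give 880 nM in this assay, with a likely range from 450 nM to 1800 nM.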

Compound 4, half-maximal inhibitory concentration: 270 nM
Beside the measured number, compound 4's estimate is 3.3-fold (0.51 log units) above it; the whole stated range lies above it.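

In this assay, putting dimethylamino in place of ethylamino gave a 3.6-fold lower number from compound 3 to compound 4 (0.56 log units; beyond the scatter), a step beyond the usual scatter on the second core. The same change therefore cannot be treated as a fixed increment that carries unchanged from one core to another in this series, as the two steps differ in size: the same change on two cores in this assay, a 1.1-fold lower number (0.05 log units; within the scatter) from compound 1 to compound 2 and a 3.6-fold lower number (0.56 log units; beyond the scatter) from compound 3 to compound 4, 3.2-fold (0.51 log units) apart, beyond the scatter of two such steps This rests on a single pair of compounds for each core, so it shows that the core can matter for the size of this step, but not why, nor how the change would behave on any further core.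

On these data alone, only ethylamino and dimethylamino appear on this side chain, so it remains open how a ring amine such as pyrrolidine or morpholine, or a larger group such as diethylamino, would fare on either core. The compounds shown also leave open which structural feature of the second core goes with the larger step.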